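The source may report more compounds than this note shows. Statements on the series, on what has been measured and on what is new or still open speak of the compounds shown alone.

Measured compounds:

compound 1 `ClCc1cccc(Cn2cnc3ncnc(Cl)c32)c1` — in a functional assay on PC-3 cells (Homo sapiens) for cytotoxicity, read by sulforhodamine B assay, with a stated time of 48 h (a lower number here means a stronger inhibitor of growth, a higher number a weaker inhibitor of growth), compound 1 gives 2130 nM
compound 2 `ClCc1cccc(Cn2cnc3c(Cl)nc(Cl)nc32)c1` — in this assay compound 2 gives 2390 nM

Only these two numbers are known, and they sit within the usual scatter of each other, so compound 1 cannot be told apart from compound 2 in this assay. Going by the values given here, no single-point step has been worked out for that pair, and no other measured compound is available to show what a change of the kind described below does.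

Compound 3 `ClCc1cccc(Cn2cnc3nc(Cl)nc(Cl)c32)c1` differs from compound 1 by chloro in place of hydrogen on an aromatic carbon, between two ring nitrogen atoms, meta to a chloro group, meta to a fused ring and para to a fused ring. Among the compounds with values here, with no measured step of this kind to draw on, and with compound 2, which also carries two chloro groups on the shared core, giving 2390 nM close to compound 1, the expected step is none beyond the scatter, in either direction.

Compound 3 is therefore estimated to give 2200 nM, with a range from 1000 nM to 5000 nM. That estimate means an expected step of a 1.0-fold higher number from compound 1 to compound 3 (0.01 log units; within the scatter), within the scatter.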

Compound 3, concentration for 50% growth inhibition: 1540 nM
Compound 3: middle estimate off by 1.4-fold (0.15 log units), on the high side; low and high end bracket the measured number.
By their numbers in this assay, from the lowest: compounds 3, 1 and 2 (each within the scatter of the next).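

In this assay, the step for chloro in place of hydrogen on an aromatic carbon, at the carbon between two ring nitrogen atoms, is a 1.4-fold lower number from compound 1 to compound 3 (0.14 log units; within the scatter). Going by these compounds alone, this is the first single-place change that can be read for this series, and it shows that this hydrogen can give way to a chloro group, on a core that already carries a chloro group meta to this carbon, with no change that can be told from the scatter. Nothing measured here bears on why the step is this small, and this single pair gives no account of it.

From the compounds shown here alone, what remains open is whether a different group on this same carbon, such as an amine, a methoxy group or a longer chain, would move the number beyond the scatter, since chloro is the only replacement for hydrogen seen here. Going by these compounds, it is also open whether the same change would give a similar step with the other chloro group replaced by an amine, or in any cell line other than this one.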